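The compounds below may be only part of what the source reports. "The series", "measured", "known", "first", "only" and "open" are said of these compounds alone.

Going by the values given here, in an ADME assay on NHDF cells (Homo sapiens) for cytotoxicity (on this read-out lower numbers stand for stronger inhibition and higher numbers for weaker inhibition), two compounds built on a shared core have numbers so far. Among the compounds with values here, compound 1 (`COc1cc(/C=C2\CCC/C(=C\c3ccc(O)c(O)c3)C2=O)cc(OC)c1OC`) gives 9000 nM, and compound 2 (`COc1cc(/C=C2\CCC/C(=C\c3ccccc3Br)C2=O)cc(OC)c1OC`) gives 12400 nM, which places compound 2 within the scatter of the only other measurement. Compound 3 (`COc1cc(/C=C2\CCC/C(=C\c3ccccc3F)C2=O)cc(OC)c1OC`) has not yet been measured. It differs from compound 2 by a single exchange, fluoro in place of bromo on an aromatic carbon, ortho to a large group. Within the data shown here, only one measured step bears on this, namely a 1.4-fold higher number from compound 1 to compound 2 (0.14 log units; within the scatter), where 2-bromophenyl stands in place of 3,4-dihydroxyphenyl. Even that exchange of the whole substituent stayed inside the scatter, so no step beyond the scatter is expected in this assay here. The expected change is a 1.1-fold lower number from compound 2 to compound 3 (0.05 log units; within the scatter). For compound 3 the estimated value is 11000 nM, with an expected range of 5500 nM to 22000 nM.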

Compound 3, half-maximal inhibitory concentration: 4000 nM
The estimate for compound 3 lay 2.8-fold (0.44 log units) above the measured number, and the stated range ends above it.
By their numbers in this assay, from the lowest: compound 3; then compounds 1 and 2 (each within the scatter of the next).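

In this assay, the aromatic carbon ortho to a large group proves sensitive to the choice of halogen, as fluoro in place of bromo gives a step beyond the scatter (a 3.1-fold lower number from compound 2 to compound 3 (0.49 log units; beyond the scatter)). The exchange of the whole substituent now also reaches beyond the scatter when 2-fluorophenyl enters in place of 3,4-dihydroxyphenyl (a 2.3-fold lower number from compound 1 to compound 3 (0.35 log units; beyond the scatter)), whereas with 2-bromophenyl it stayed within the scatter (a 1.4-fold higher number from compound 1 to compound 2 (0.14 log units; within the scatter)). No measurement at hand accounts for the difference between fluoro and bromo at this position.

With only these two halogens compared on this carbon, the compounds shown do not tell whether the numbers would fall in step along the halogens. Chloro, a methoxy group or an amine on the same carbon remains an open case.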